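The source may hold more compounds than are shown below. What is called first, only, known or untested is meant among the compounds shown, and "the series" means these compounds.

Compound 1, `CC1=C(C(=O)Nc2ccc(Br)cc2)C(c2ccc(Cl)cc2Cl)N=C(SCc2ccc(F)cc2)N1`: 23.1%
Compound 2, `COc1ccc(C2N=C(SCc3ccc(Cl)cc3)NC(C)=C2C(=O)Nc2ccc(Br)cc2)cc1`: 20%

Both compounds were examined in a functional assay on the whole organism (artery, strain albino) with Rattus norvegicus as the target, with a stated time of 900 min, at a dose of 10 mg/kg by the oral route; on this read-out higher numbers stand for more inhibition at the one dose given (going by the name of the read-out) and lower numbers for less inhibition. In this assay compound 1 gives 23.1%, and compound 2 gives 20%. As the numbers stand, compound 2 has the lower of the two values, but its gap to compound 1, its only neighbor, lies within the usual scatter of repeated measurements, so the two cannot be told apart on this read-out. Within the data shown here, compounds 1 and 2 also differ in more than one place, so no single-change step between measured compounds is available to guide the next move.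

Compound 3, `COc1ccc(C2N=C(SCc3ccc(F)cc3)NC(C)=C2C(=O)Nc2ccc(Br)cc2)cc1`, has not yet been measured in this assay. It differs from compound 2 in one place: fluoro in place of chloro on an aromatic carbon. Compound 1, which already carries the 4-fluorobenzyl group on a different core, sits within the scatter of compound 2, which offers no hint of a marked shift in either direction. The step from compound 2 to compound 3 is expected to be a number 2 percentage points higher from compound 2 to compound 3 (within the scatter), which is no change beyond the scatter. Compound 3 is therefore estimated at 22%, with a range from 8% to 38%.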

Compound 3, a percentage reported as inhibition, in the whole organism at one dose (the size of the read-out at that dose, not a potency): 15.4%
Estimate against measurement, compound 3: 6.6 percentage points above; low and high end bracket the measured number.
By their numbers in this assay, from the lowest: compounds 3, 2 and 1 (each within the scatter of the next).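

Among these compounds, the swap of fluoro for chloro on an aromatic carbon, para to a large group, gives the first reading of a single change at this position: in this assay it amounts to a number 4.6 percentage points lower from compound 2 to compound 3 (within the scatter). With compound 3 in hand, the 4-chlorobenzyl and 4-fluorobenzyl forms of the sulfanyl substituent cannot be told apart on this read-out, so this exchange of one halogen for the other leaves no mark beyond the scatter. The second new step, 4-methoxyphenyl in place of 2,4-dichlorophenyl on a saturated ring carbon, comes to a number 7.7 percentage points lower from compound 1 to compound 3 (within the scatter), so this change of the aryl group, with the 4-fluorobenzyl group held constant, does not separate the two compounds either, and nothing independent of these numbers bears on the result.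

On these data alone, only two halogens have been seen at the position para to a large group, so it stays open whether an amine or a carboxylic acid there would shift the number beyond the scatter. Equally open, as far as these compounds go, is whether a longer chain in place of the benzyl group would do so.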